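Two Sulfone Amides Measured, a Third Still Awaited

The compounds below may be only part of what the source reports. "The series", "measured", "known", "first", "only" and "open" are said of these compounds alone.

compound 1 `O=C(NCc1ccc(S(=O)(=O)c2ccccc2)cc1)c1cc(-c2cccnc2)[nH]n1`: 42%
compound 2 `Cc1cccc(S(=O)(=O)c2ccc(CNC(=O)c3cc4cnccc4[nH]3)cc2)c1`: 32%

In an ADME assay on microsomes from liver (Mus musculus) for metabolic stability, read by LC-MS, with a stated time of 30 min, tested at 1 uM (a lower number here means that less of the compound is left, a higher number that more of the compound is left), compound 1 gives 42%, and compound 2 gives 32%. Compound 2 thus has the smaller of the two figures, but its gap to compound 1 lies within the scatter, so the two cannot be told apart on these numbers. The two compounds also differ in their cores, so no single change between them is counted.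

Compound 3 `O=C(NCc1ccc(S(=O)(=O)c2ccccc2C(F)(F)F)cc1)c1cc2cnccc2[nH]1` shares the core of compound 2 and differs from it in one place: 2-(trifluoromethyl)phenyl in place of 3-methylphenyl on a sulfonyl sulfur. Among the compounds with values here, no step between measured compounds is available to guide this change, and nothing in the two numbers so far points either way. The expected step is therefore none beyond the scatter, with the estimate a number 3 percentage points higher from compound 2 to compound 3 (within the scatter) in this assay. Compound 3 is expected to give 35%, within a range from 18% to 55%.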

Compound 3, percent of the compound remaining: 41%
The estimate for compound 3 lay 6 percentage points below the measured number; the measured number falls inside the stated range.
By their numbers in this assay, from the lowest: compounds 2, 3 and 1 (each within the scatter of the next).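

Within the data shown here, this is the first comparison in the set that differs in one place only. In this assay, 2-(trifluoromethyl)phenyl in place of 3-methylphenyl on a sulfonyl sulfur gives a number 9 percentage points higher from compound 2 to compound 3 (within the scatter) and so does not separate the two compounds. On the core shared by compound 2 and compound 3, this exchange therefore leaves no readable difference in the percent of compound remaining, although both the group and its substituent differ. No measurement at hand speaks to the reason for this result.

Going by these compounds, whether a plain phenyl on the same sulfonyl sulfur would also stay within the scatter remains open. So does the question of whether an aryl group carrying an amine or a carboxylic acid would give a step beyond it.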